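Cytotoxicity on rat muscle cells: swapping a bromophenyl for difluorophenyl

The source may hold more compounds than are shown below. What is called first, only, known or untested is meant among the compounds shown, and "the series" means these compounds.

Measured so far:
- Compound 1, `C/C(=N\N=C(/N)CC(O)c1cccc2ccccc12)c1ccc(F)cc1`: 34000 nM
- Compound 2, `N/C(CC(O)c1cccc2ccccc12)=N\N=C\c1cccc(Br)c1`: 3900 nM
- Compound 3, `N/C(CC(O)c1ccc2ccccc2c1)=N\N=C\c1ccc(F)cc1F`: 93000 nM

All three compounds were tested in an ADME assay on L6 cells (Rattus norvegicus) for cytotoxicity, read by resazurin assay, with a stated time of 72 h; a lower number here means a stronger inhibitor, a higher number a weaker inhibitor. Among the three numbers, compound 2 stands lowest, and both gaps from it lie beyond the scatter: compound 1 sits well above it, and compound 3 sits furthest above it. Among the compounds with values here, no pair of these measured compounds differs in a single place, so no clean step between them can be drawn.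

Compound 4, `N/C(CC(O)c1cccc2ccccc12)=N\N=C\c1ccc(F)c(F)c1`, has not yet been measured in this assay. It differs from compound 2 in one place: 3,4-difluorophenyl in place of 3-bromophenyl on a carbon with a double bond to nitrogen. Within the data shown here, no measured pair reports this change directly. What the numbers do show is that the two compounds carrying fluorine on that ring, compound 1 and compound 3, both give higher numbers than compound 2. On that basis a step upward from compound 2 to compound 4 is expected, of moderate size and beyond the scatter, a 3.8-fold higher number from compound 2 to compound 4 (0.59 log units; beyond the scatter). Compound 4 is therefore estimated at 15000 nM, within a range from 4000 nM to 60000 nM.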

Compound 4, half-maximal inhibitory concentration: 17000 nM
The estimate for compound 4 lay 1.1-fold (0.05 log units) below the measured number, and the stated range covers the measured number.
By their numbers in this assay, from the lowest: compound 2; then compounds 4 and 1 (each within the scatter of the next); then compound 3.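

Within the data shown here, this pair gives the first clean single-change comparison in this assay: placing 3,4-difluorophenyl in place of 3-bromophenyl on a carbon with a double bond to nitrogen gives a 4.4-fold higher number from compound 2 to compound 4 (0.64 log units; beyond the scatter). The rest of the molecule stays the same, so this one exchange accounts for a modest shift that lies beyond the usual scatter. The group at this position can therefore change the cytotoxicity reading, but nothing shown here says why this step occurs.

As far as these compounds go, whether a plain phenyl, a 3-chlorophenyl or a phenyl carrying an amine would give a number nearer compound 2 or compound 4 remains open. Also open, from the compounds shown here alone, is whether the same exchange would produce a step of similar size on the core of compound 3.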